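Chloro to methyl swap across two cores in stability

This account rests on a few compounds, and the source may have more. Where it says the series, first, only, none or still open, it means among the compounds named here.

Three compounds are in hand. Compound 1 `CC(=O)Nc1cc(-c2ccc(OC[C@@H](N)CC(C)C)c(C)c2)ccn1` and compound 2 `CC(=O)Nc1cc(-c2ccc(OC[C@@H](N)CC(C)C)c(Cl)c2)ccn1` share one core, while compound 3 `Cc1cc(-c2cc(Cl)c(OC[C@@](C)(N)CC(C)C)cn2)ccn1` is built on a different core; the difference between the two cores is not broken down here. In an ADME assay on microsomes from liver (Rattus norvegicus) for metabolic stability, read by LC-MS, using NADPH, with a stated time of 10 min, tested at 0.5 uM (on this read-out higher numbers stand for a more stable compound and lower numbers for a less stable compound), compound 1 gives 99% and compound 2 gives 100%. Between these two the step is a number 1 percentage points lower from compound 2 to compound 1 (within the scatter), the change being (methyl in place of chloro on an aromatic carbon). In this assay compound 3 gives 73%, the lowest of the three numbers; its gap to compound 1 and to compound 2 is beyond the scatter in each case.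

Compound 4 `Cc1cc(-c2cc(C)c(OC[C@@](C)(N)CC(C)C)cn2)ccn1` has not yet been run. It differs from compound 3 by methyl in place of chloro on an aromatic carbon. This is the same kind of change as that from compound 2 to compound 1, but not the same: in compound 1 it sits on a six-membered aromatic ring of carbon only, ortho to a (2-amino-4-methylpentyl)oxy group and meta to a large group, whereas in compound 4 it sits on a six-membered aromatic ring with one nitrogen, ortho to a group of nine heavy atoms, meta to a 2-methylpyridin-4-yl group and opposite the ring nitrogen.

The step from compound 3 to compound 4 is expected to be a number 1 percentage points higher from compound 3 to compound 4 (within the scatter) because a number 1 percentage points lower from compound 2 to compound 1 (within the scatter) is all that the same kind of change produced on the first core, and nothing among these compounds points to a different outcome on the second core. In this assay compound 4 is therefore estimated at 74%, expected to fall between 58% and 90%.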

Compound 4, percent of the compound remaining: 72%
The estimate for compound 4 lay 2 percentage points above the measured number, within the range that was stated.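

In this assay, methyl in place of chloro on the aromatic carbon opposite the ring nitrogen gives a number 1 percentage points lower from compound 3 to compound 4 (within the scatter), so on this second core the swap again leaves the percent remaining within the scatter. Set beside the step on the first core, the result shows no difference between the two cores beyond the scatter: the same change on two cores in this assay, a number 1 percentage points lower (within the scatter) from compound 2 to compound 1 and a number 1 percentage points lower (within the scatter) from compound 3 to compound 4, 0 percentage points apart, within the scatter of two such steps This supports treating chloro and methyl as interchangeable for this read-out in these two matched pairs, but it rests on only two pairs, one of which stands near the top of the percent scale with compound 2 at 100%, and it does not establish that the swap would behave the same way on any further core or in any other assay, nor does it give a reason for the result.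

On these data alone, whether a fluoro, methoxy or nitrile group on the same aromatic carbon would also stay within the scatter remains open. Also open is which of the structural differences between the two cores goes with the lower numbers of compound 3 and compound 4, as the compounds shown include no pair that differs at only one of those places.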